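Compound 1 to compound 3: methoxy to cyano

The source may hold more compounds than are shown below. What is called first, only, known or untested is meant among the compounds shown, and "the series" means these compounds.

Measured in a physicochemical assay for lipophilicity, at pH 7.4; a higher number here means a more lipophilic compound, a lower number a more polar compound:
- compound 1 `COc1ccc(C2(C(=O)N3CCC[C@@H]3C(=O)Nc3ccc4[nH]ncc4n3)CCC2)cc1`: 3.9
- compound 2 `O=C(Nc1ccc2[nH]nnc2c1)[C@H]1CCCN1C(=O)C1(c2cccc(Cl)c2)CCCC1`: 5.2

Compound 1 holds the lower of the two numbers at 3.9, and compound 2 stands at 5.2, a gap beyond the usual scatter. These two compounds differ in more than one place, so their gap gives no measure of any single change.

Next in line is compound 3 `N#Cc1ccc(C2(C(=O)N3CCC[C@@H]3C(=O)Nc3ccc4[nH]ncc4n3)CCC2)cc1`, with cyano in place of methoxy on an aromatic carbon, para to a large group: cyano in place of methoxy on an aromatic carbon. Among the measured compounds shown here, no measured pair isolates this change, so the expectation rests on the structural change alone. A modest step down in this assay is expected, slightly beyond the scatter. The estimated size is a number 0.40 log units lower from compound 1 to compound 3 (beyond the scatter). For compound 3 the expected value is 3.5, with an estimated range of 3.1 to 3.9.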

Compound 3, distribution coefficient: 3.4
The estimate for compound 3 lay 0.10 log units above the measured number, and the stated range covers the measured number.
By their numbers in this assay, from the lowest: compound 3; then compound 1; then compound 2.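

Working notes on this position: in this assay, the change from 4-methoxyphenyl to 4-cyanophenyl gives a number 0.50 log units lower from compound 1 to compound 3 (beyond the scatter) as the first step in the series that can be read at a single place, so the group para to a large group on this aromatic ring does register in this read-out. Methoxy and cyano both count 2 heavy atoms and 1 hydrogen-bond acceptor, so the step arises with these counts unchanged. No measured evidence bears on the origin of this step.

Among the compounds shown here, with only one step at this position, how an amine, a carboxylic acid or a longer chain such as ethoxy would compare at the same place stays open. Also open, on these data alone, is whether the same change would give a step of similar size on the core of compound 2.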